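Heteroaryl Swap on the Chain Carbon of Compound 3

The source may hold more compounds than are shown below. What is called first, only, known or untested is meant among the compounds shown, and "the series" means these compounds.

Compound 3 `CC(C)C(c1ccc(-c2ccc3cccc(F)c3c2)[nH]c1=O)N1CCN/C1=N\C#N` is the analogue with the cyanoimino-bearing non-aromatic ring. In an assay on CHO cells for displacement of a labelled ligand from prostaglandin E2 receptor EP3 subtype (Homo sapiens), read by radioligand binding (a higher number here means a weaker inhibitor, a lower number a stronger inhibitor), compound 3 gives 23 nM, the highest of the three numbers at hand. Compound 1 `CC(C)C(Nc1nnc[nH]1)c1ccc(-c2ccc3cccc(F)c3c2)[nH]c1=O` gives 22 nM, a number within the scatter of that of compound 3, and compound 2 `CCn1ncc2c(C)cc(-c3ccc([C@@]4(C)CCNC4=O)c(=O)[nH]3)cc21` gives 5 nM, a lower number beyond the scatter.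

Compound 4 `CC(C)C(c1noc(=O)[nH]1)c1ccc(-c2ccc3cccc(F)c3c2)[nH]c1=O` differs from compound 3 by a group of 6 heavy atoms (2 carbon, 2 nitrogen, 2 oxygen; one five-membered aromatic ring with 3 hetero atoms) in place of a group of 8 heavy atoms (4 carbon, 4 nitrogen; one five-membered non-aromatic ring with 2 hetero atoms), on a saturated chain carbon bound to an aromatic carbon and a saturated chain carbon. Within the data shown here, the one measured step that bears on this position is the exchange of the aromatic triazole for the non-aromatic ring, a 1.0-fold higher number from compound 1 to compound 3 (0.02 log units; within the scatter), which left the number unchanged. The group entering compound 4 again is a five-membered aromatic ring with three hetero atoms and one hydrogen-bond donor, so it resembles the group of compound 1 more than that of compound 3. The step is therefore expected to stay within the scatter, with no clear direction, as a 1.2-fold lower number from compound 3 to compound 4 (0.06 log units; within the scatter). Compound 4 is accordingly estimated at 20 nM, within a range from 8 nM to 50 nM.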

Compound 4, inhibition constant: 15 nM
Estimate against measurement, compound 4: 1.3-fold (0.12 log units) above, and the stated range covers the measured number.
By their numbers in this assay, from the lowest: compound 2; then compounds 4, 1 and 3 (each within the scatter of the next).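

At the saturated chain carbon bound to an aromatic carbon and a saturated chain carbon, this assay now gives a second reading of an exchange between the non-aromatic ring and an aromatic one: a 1.5-fold lower number from compound 3 to compound 4 (0.19 log units; within the scatter) agrees with the earlier step in staying small. The result also adds a comparison of two five-membered aromatic rings, with 2 oxygen and 2 nitrogen entering in place of 4 nitrogen, and a 1.5-fold lower number from compound 1 to compound 4 (0.17 log units; within the scatter) shows that this exchange too makes no clear difference, so all three groups at this carbon give numbers within the scatter of one another. Nothing at hand gives a reason for this sameness.

The compounds shown leave open whether a group without a ring, such as a carboxylic acid or a primary amine, would fit the same pattern at this carbon. They also leave open whether the pattern would hold for a tetrazole.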